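The source may hold more compounds than are shown below. What is called first, only, known or untested is meant among the compounds shown, and "the series" means these compounds.

Compound 2 `N#CC1=C(N)N(c2ccc(S(N)(=O)=O)cc2)C2=C(CCCC2)C1c1c(O)ccc2ccccc12` in a functional assay on Ehrlich cells (Mus musculus) for cytotoxicity, read by trypan blue exclusion, with a stated time of 2 h, tested at 25 ug/mL (a higher number here means a stronger effect of the compound at the concentration tested, a lower number a weaker effect), gives 5%. Within the data shown here, its only measured neighbour, compound 1 `N#CC1=C(N)N(c2ccc(S(N)(=O)=O)cc2)C2=C(CCCC2)C1c1ccccc1`, gives 10% in this assay; the two numbers lie within the usual scatter of each other, as the step of a number 5 percentage points lower from compound 1 to compound 2 (within the scatter) shows. Compound 3 `N#CC1=C(N)N(c2ccc(S(N)(=O)=O)cc2)C2=C(CCCC2)C1c1cccs1` has not yet been measured. It differs from compound 2 by thiophen-2-yl in place of 2-hydroxynaphthalen-1-yl on a saturated ring carbon. Among the measured compounds shown here, only that one earlier step, which also exchanged the group on a saturated ring carbon, bears on this change, and it was small. Compound 3 is therefore expected to give about 8% in this assay, between 0% and 20%. The expected step of a number 3 percentage points higher from compound 2 to compound 3 (within the scatter) should stay within the scatter.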

Compound 3, a percentage reported as activity, at one concentration (the size of the read-out at that concentration, not a potency): 5%
For compound 3 the middle estimate is 3 percentage points above the measured one; low and high end bracket the measured number.
By their numbers in this assay, from the lowest: compounds 2, 3 and 1 (each within the scatter of the next).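

In this assay, this saturated ring carbon has now carried three different aromatic groups without any step leaving the scatter. Going from 2-hydroxynaphthalen-1-yl, with 11 heavy atoms, to thiophen-2-yl, with 5, gives no change at the digits printed from compound 2 to compound 3 (within the scatter), while exchanging phenyl for thiophen-2-yl gives a number 5 percentage points lower from compound 1 to compound 3 (within the scatter). No available evidence explains these results. Still open, going by these compounds, is what a non-aromatic group at this carbon, such as an amine, a carboxylic acid or a longer chain, would do to the number.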